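Compound 1 to compound 4: trifluoromethyl for trifluoromethoxy

The source may hold more compounds than are shown below. What is called first, only, known or untested is meant among the compounds shown, and "the series" means these compounds.

In an in vitro ADME assay on microsomes (Homo sapiens) for metabolic stability (a higher number here means that the compound lasts longer, a lower number that the compound disappears faster), compound 1 `CCc1nc(-c2ccc(OC(F)(F)F)cc2OC)c(CC)nc1NC(CC)CC` gives 0.217 h as the lowest of three numbers. Compound 2 `CCc1nc(-c2ccc(OC(F)(F)F)cc2OC)c(OC)nc1NC(CC)CC` gives 0.867 h and compound 3 `CCc1nc(-c2ccc(Cl)cc2Cl)c(OC)nc1NC(CC)CC` without trifluoromethoxy gives 0.7 h as a close number. Compound 4 `CCc1nc(-c2ccc(C(F)(F)F)cc2OC)c(CC)nc1NC(CC)CC` differs from compound 1 by trifluoromethyl in place of trifluoromethoxy on an aromatic carbon with trifluoromethyl in place of trifluoromethoxy on an aromatic carbon. Among the compounds with values here, the only measured step is a 4.0-fold higher number from compound 1 to compound 2 (0.60 log units; beyond the scatter) with methoxy in place of ethyl, a modest step at another place. Within the data shown here, no measured step touches the trifluoromethoxy group, and compound 4 keeps the ethyl of compound 1 at 0.217 h as its reference. The expected result is a 1.2-fold higher number from compound 1 to compound 4 (0.06 log units; within the scatter) and so no step beyond the scatter in this assay is anticipated. Compound 4 is estimated at 0.25 h with an expected range from 0.13 h to 0.48 h for this swap.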

Compound 4, half-life: 0.183 h
Compound 4: middle estimate off by 1.4-fold (0.14 log units), on the high side, within the range that was stated.
By their numbers in this assay, from the lowest: compounds 4 and 1 (each within the scatter of the next); then compounds 3 and 2 (each within the scatter of the next).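

In this assay, the change at the aromatic carbon para to a large group gives a 1.2-fold lower number from compound 1 to compound 4 (0.07 log units; within the scatter), so with ethyl on the shared core, trifluoromethyl and trifluoromethoxy cannot be told apart at this position. Losing the oxygen of trifluoromethoxy therefore leaves the read-out within the scatter, whereas methoxy in place of ethyl gives a 4.0-fold higher number from compound 1 to compound 2 (0.60 log units; beyond the scatter). No measurement on hand bears on the reason for this result. On these data alone, whether trifluoromethyl reads the same alongside methoxy in place of ethyl, as in compound 2, remains open. As far as these compounds go, how a nitrile or a longer chain would read at this position also remains open.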